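Two distant scaffolds, one unmeasured amide variant

The source may hold more compounds than are shown below. What is called first, only, known or untested is meant among the compounds shown, and "the series" means these compounds.

Measured so far:
Compound 1, `O=C1c2cc(OCCC3CCN(Cc4ccc(C5=NCCN5)cc4)CC3)ccc2CCCN1Cc1ccccc1`, in an assay on CHO cells for inhibition of melanin-concentrating hormone receptor 1 (Homo sapiens) (a higher number here means a weaker inhibitor, a lower number a stronger inhibitor), gives 300 nM.
Compound 2, `CCN1CCN(c2cc(C)c3cc(NC(=O)CSc4ccncc4)ccc3n2)CC1`, in this assay gives 8200 nM.

Compound 2 holds the highest of the two numbers, and compound 1 sits far lower, beyond the scatter. The two share no common core, so nothing links their values. Compound 3, `CCN1CCN(c2cc(C)c3cc(NC(=O)C(C)Oc4ccc(Cl)cc4Cl)ccc3n2)CC1`, keeps the core of compound 2 and changes only the amide: 1-(2,4-dichlorophenoxy)ethyl in place of ((pyridin-4-yl)sulfanyl)methyl on a carbonyl carbon. Within the data shown here, no comparable step has been measured, so the expected step of a 2.7-fold lower number from compound 2 to compound 3 (0.44 log units; beyond the scatter) is an estimate rather than a pattern. Compound 3 is expected to give about 3000 nM, within a range from 500 nM to 15000 nM.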

Compound 3, half-maximal inhibitory concentration: 230 nM
Beside the measured number, compound 3's estimate is 13-fold (1.12 log units) above it, outside the stated range (below it).
By their numbers in this assay, from the lowest: compounds 3 and 1 (each within the scatter of the next); then compound 2.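

On a carbonyl carbon whose other neighbour is an amide-type nitrogen, putting 1-(2,4-dichlorophenoxy)ethyl in place of ((pyridin-4-yl)sulfanyl)methyl gives a 36-fold lower number from compound 2 to compound 3 (1.55 log units; beyond the scatter) in this assay and so shows that this one place can carry a large change while the core stays fixed. The swap alters several things at once, including the ring, the sulfur and the chlorines, so the step cannot be assigned to any one of them. Nothing on hand explains its size. From the compounds shown here alone, whether the chlorine atoms are needed remains open, as does what a plain phenoxymethyl group, an amine or a carboxylic acid would give at this place.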